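Replacing isopropoxymethyl with oxolan-2-yl

This account rests on a few compounds, and the source may have more. Where it says the series, first, only, none or still open, it means among the compounds named here.

In a functional assay on FaDu cells (Homo sapiens) for cytotoxicity, read by MTT assay, with a stated time of 72 h (a lower number here means that less compound is tolerated, a higher number that more compound is tolerated), compound 1 `COc1ccc(NC(=O)C(=O)c2cn(CC3CCO3)c3ccccc23)cn1` gives 686 nM, compound 2 `COc1ccc(NC(=O)C(=O)c2cn(C3CCCC3)c3ccccc23)cn1` gives 370 nM and compound 3 `COc1ccc(NC(=O)C(=O)c2cn(CCOC(C)C)c3ccccc23)cn1` gives 211 nM. Compound 3 thus sits at the low end of this small set, though compound 2 cannot be told apart from it, with a 1.8-fold lower number from compound 2 to compound 3 (0.24 log units; within the scatter). Only compound 1 stands clearly apart, with a 3.3-fold lower number from compound 1 to compound 3 (0.51 log units; beyond the scatter).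

Compound 4 `COc1ccc(NC(=O)C(=O)c2cn(CC3CCCO3)c3ccccc23)cn1` differs from compound 3 in one place: oxolan-2-yl in place of isopropoxymethyl on a saturated chain carbon bound to an aromatic nitrogen. This puts oxolan-2-yl in place of isopropoxymethyl on a saturated chain carbon bound to an aromatic nitrogen.

Going by the values given here, the most relevant measured step is the one from compound 1, which carries oxetan-2-yl at that carbon, and it is only modest: a 3.3-fold lower number from compound 1 to compound 3 (0.51 log units; beyond the scatter). The step involving cyclopentyl, a 1.9-fold lower number from compound 1 to compound 2 (0.27 log units; within the scatter), stays within the scatter and adds little. Compound 4 has a ring at that carbon, as compound 1 does, so a small rise from compound 3 is expected in this assay, smaller than the gap to compound 1 and probably not clearly beyond the scatter. The expected change is a 1.6-fold higher number from compound 3 to compound 4 (0.21 log units; within the scatter). For compound 4 the estimated value is 340 nM, with an expected range of 160 nM to 750 nM.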

Compound 4, concentration lethal to 50% of the cells: 31 nM
Beside the measured number, compound 4's estimate is 11-fold (1.04 log units) above it; measured number below the stated range.
By their numbers in this assay, from the lowest: compound 4; then compounds 3, 2 and 1 (each within the scatter of the next, the first and the last beyond it).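

In this assay, going by these compounds alone, the exchange of isopropoxymethyl for oxolan-2-yl leaves the counts of heavy atoms, carbon, oxygen and hydrogen-bond acceptors unchanged and still gives a 6.8-fold lower number from compound 3 to compound 4 (0.83 log units; beyond the scatter), so at this place the arrangement of those atoms into a five-membered ring matters in a way the earlier compounds did not reveal. A ring on that saturated chain carbon does not by itself give a low number, since compound 1 also has one there and the change of oxetan-2-yl to oxolan-2-yl gives a 22-fold lower number from compound 1 to compound 4 (1.34 log units; beyond the scatter), while (oxolan-2-yl)methyl in place of cyclopentyl on the aromatic nitrogen gives a 12-fold lower number from compound 2 to compound 4 (1.08 log units; beyond the scatter). Nothing available explains why this one ring stands apart from the other groups.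

The compounds shown leave open whether the ring oxygen is needed, which cyclopentylmethyl on the aromatic nitrogen would test, and whether the five-membered ring is the best size, which oxan-2-yl would test. They also leave open whether the position of the oxygen matters, as oxolan-3-yl would show, and whether a ring nitrogen could take its place, as in pyrrolidin-2-yl.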